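The source may hold more compounds than are shown below. What is called first, only, known or untested is meant among the compounds shown, and "the series" means these compounds.

Compound 2 `Cc1cnc(Nc2ccc(S(C)(=O)=O)cc2)nc1Nc1nc2ccc(Cl)cc2s1` gives 4320 nM in a functional assay on MCF7 cells (Homo sapiens) for antiproliferative activity, read by MTT assay, with a stated time of 48 h (on this read-out lower numbers stand for stronger inhibition and higher numbers for weaker inhibition), the lowest of the two numbers recorded; compound 1 `Cc1ccc2nc(Nc3nc(Nc4ccc(S(N)(=O)=O)cc4)ncc3F)sc2c1` gives 24500 nM in this assay, a clearly higher number. Compound 3 `Cc1ccc2nc(Nc3nc(Nc4ccc(S(N)(=O)=O)cc4)ncc3C)sc2c1` reaches only a limit of this assay, > 50000 nM. Within the data shown here, the single measured step, an at least 2.0-fold higher number from compound 1 to compound 3 (0.30 log units; that floor lies within the scatter), concerns a different position and a different kind of exchange. Compound 4 `Cc1cnc(Nc2ccc(S(C)(=O)=O)cc2)nc1Nc1nc2ccccc2s1` differs from compound 2 by hydrogen in place of chloro on an aromatic carbon. Among the measured compounds shown here, no measured step bears on this change, so no movement beyond the scatter is expected for compound 4 in this assay, with at most a slightly higher number. Compound 4 is therefore expected to give about 6500 nM in this assay, between 2500 nM and 18000 nM. The expected step is a 1.5-fold higher number from compound 2 to compound 4 (0.18 log units; within the scatter).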

Compound 4, half-maximal inhibitory concentration: 6550 nM
Compound 4: the middle estimate sits 1.0-fold (0.00 log units) below what was measured; measured number inside the range.
By their numbers in this assay, from the lowest: compounds 2 and 4 (each within the scatter of the next); then compound 1. At a limit, above all of these: compound 3.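

Hydrogen in place of chloro on this aromatic carbon gives a 1.5-fold higher number from compound 2 to compound 4 (0.18 log units; within the scatter) in this assay, so at this position the chloro is not needed for a number of this size. Among these compounds, this is the only measured change at this position, since the earlier step concerned another place and another exchange. Nothing available here gives a cause for the result.

Still open, on these data alone, is whether an amine, a methoxy group or a carboxylic acid on this carbon would move the number beyond the scatter. Also open, as far as these compounds go, is how a longer chain there would compare with chloro and hydrogen.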